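Ethyl on the amide nitrogen: an untested change

The source may report more compounds than this note shows. Statements on the series, on what has been measured and on what is new or still open speak of the compounds shown alone.

Compound 3 `CC(C)OC(=O)N1CCC(n2ncc3cc(-c4cc(F)c(C(N)=O)cc4F)ncc32)CC1` is measured in a functional assay on HEK293 cells for agonist activity at Glucose-dependent insulinotropic receptor (Homo sapiens), read by cAMP accumulation, with a stated time of 30 min (on this read-out lower numbers stand for an effect already at smaller amounts and higher numbers for an effect only at larger amounts of compound), at 52 nM. Compound 1 `CC(C)(C)OC(=O)N1CCC(n2nnc3cc(-c4ccc(S(C)(=O)=O)cc4)ccc32)CC1` gives 63 nM in this assay, and compound 2 `CC(C)OC(=O)N1CCC(n2ncc3cc(-c4ccc(C(N)=O)cc4F)ncc32)CC1` gives 97 nM; all three numbers lie within the scatter of one another, so none stands apart. Among the compounds with values here, the one single-point step among them is a 1.9-fold lower number from compound 2 to compound 3 (0.27 log units; within the scatter), a change within the scatter.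

Compound 4 `CCNC(=O)c1cc(F)c(-c2cc3cnn(C4CCN(C(=O)OC(C)C)CC4)c3cn2)cc1F` differs from compound 3 by ethyl in place of hydrogen on an amide-type nitrogen. Within the data shown here, no measured pair touches the amide nitrogen: the step from compound 2 to compound 3 concerns a fluoro on an aromatic carbon and says nothing about an ethyl on the carbamoyl group. The expectation therefore rests on compound 3 alone, with a wide range to cover the missing precedent. Compound 4 is expected to give about 80 nM in this assay, somewhere between 25 nM and 300 nM. The step this estimate implies, a 1.5-fold higher number from compound 3 to compound 4 (0.19 log units; within the scatter), is expected to stay close to the scatter, with no direction favoured by the data.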

Compound 4, half-maximal effective concentration: 10 nM
Compound 4: middle estimate off by 8.0-fold (0.90 log units), on the high side; the measured number lies below the stated range.
By their numbers in this assay, from the lowest: compound 4; then compounds 3, 1 and 2 (each within the scatter of the next).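

In this assay, ethyl in place of hydrogen on the amide-type nitrogen gives a 5.2-fold lower number from compound 3 to compound 4 (0.72 log units; beyond the scatter) and is the only step among the compounds shown that lies beyond the scatter. The carbamoyl group of compound 3 is therefore a place where a change moves the number, and here the ethylcarbamoyl group of compound 4 moves it downward rather than upward. No supporting data are available to account for this change in the number.

Going by these compounds, it remains open whether the lower number is particular to ethyl or also holds for a methyl, a longer chain such as propyl, or a cyclopropyl ring on the same nitrogen. On these data alone, with a single pair, it is also open whether ethyl would have a similar effect on compound 2, which carries one fluoro fewer.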